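Removing One Fluorine from a Legumain Nitrile Inhibitor

The source may report more compounds than this note shows. Statements on the series, on what has been measured and on what is new or still open speak of the compounds shown alone.

Going by the values given here, compound 1 `C[C@@H](C(=O)N[C@H](C#N)CC(N)=O)N(Cc1ccc(-c2ccc(F)c(F)c2)cc1)S(C)(=O)=O` gives 252 nM in an assay on isolated protein for inhibition of legumain (Homo sapiens), with stated times of 2 min and 60 min (a higher number here means a weaker inhibitor, a lower number a stronger inhibitor), the lowest of the three numbers measured so far. Its stereoisomer, compound 2 `C[C@H](C(=O)N[C@H](C#N)CC(N)=O)N(Cc1ccc(-c2ccc(F)c(F)c2)cc1)S(C)(=O)=O`, gives 6300 nM in this assay, and the step of a 25-fold higher number from compound 1 to compound 2 (1.40 log units; beyond the scatter) rests on (the fact that compounds 1 and 2 differ only in the configuration as drawn). Compound 3 `CC(C(=O)N[C@H](C#N)CC(N)=O)N(Cc1ccc(-c2cccc(Cl)c2)cc1)S(C)(=O)=O` gives 425 nM in this assay, a number within the scatter of compound 1. Compound 4 `C[C@@H](C(=O)N[C@H](C#N)CC(N)=O)N(Cc1ccc(-c2ccc(F)cc2)cc1)S(C)(=O)=O` differs from compound 1 by hydrogen in place of fluoro on an aromatic carbon. Among the compounds with values here, no measured step in this set touches that group: the only measured step concerns configuration alone, and compound 3 differs from compound 1 in another place. The change is therefore expected to stay within the scatter, with compound 4 estimated at 350 nM, between 150 nM and 900 nM. The expected step is a 1.4-fold higher number from compound 1 to compound 4 (0.14 log units; within the scatter).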

Compound 4, half-maximal inhibitory concentration: 1040 nM
Beside the measured number, compound 4's estimate is 3.0-fold (0.47 log units) below it, outside the stated range (above it).
By their numbers in this assay, from the lowest: compounds 1 and 3 (each within the scatter of the next); then compound 4; then compound 2.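

Replacing fluoro with hydrogen on this aromatic carbon, ortho to a fluoro group, gives a 4.1-fold higher number from compound 1 to compound 4 (0.62 log units; beyond the scatter) in this assay. The earlier compounds shown here measured only a change of configuration, whereas this step shows that the 3,4-difluorophenyl to 4-fluorophenyl change, a loss of one heavy atom, also moves the number beyond the scatter. Nothing given here bears on why the number rises. The compounds shown leave open whether chloro, methyl or methoxy on this carbon would match compound 1. They also leave open what removing the remaining fluoro of compound 4 would do.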